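The source may report more compounds than this note shows. Statements on the series, on what has been measured and on what is new or still open speak of the compounds shown alone.

Measured so far:
Compound 1 `COc1ccc(C(=O)c2ccc(OC)c3c2C=CC(C)(C)O3)c(NC(=O)CO)c1` gives 420 nM in a functional assay on A2780 cells (Homo sapiens) for antiproliferative activity, read by MTT assay, with a stated time of 48 h; a lower number here means a stronger inhibitor, a higher number a weaker inhibitor.
Compound 2 `CNCC(=O)Nc1cc(OC)ccc1C(=O)c1ccc(OC)c2c1C=CC(C)(C)O2` gives 1590 nM in this assay.
Compound 3 `COc1ccc(C(=O)c2cc(OC)c(OC)c(OC)c2)c(NC(=O)CO)c1` gives 100 nM in this assay.

Compound 3 carries the lowest number of the three, and its gaps to compound 1 and to compound 2 both lie beyond the scatter, so it is the strongest inhibitor of the measured set. Compound 1 and compound 2 share one core and differ in a single place: methylamino in place of hydroxy on a saturated chain carbon bound to a carbonyl carbon. That change produced a 3.8-fold higher number from compound 1 to compound 2 (0.58 log units; beyond the scatter), a modest weakening. How the core of compound 3 differs from the core of compound 1 is not broken down here.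

Compound 4 `CNCC(=O)Nc1cc(OC)ccc1C(=O)c1cc(OC)c(OC)c(OC)c1` is compound 3 with the same change applied: methylamino in place of hydroxy on a saturated chain carbon bound to a carbonyl carbon. Because the change sits in the same place and the earlier pair moved by a 3.8-fold higher number from compound 1 to compound 2 (0.58 log units; beyond the scatter), the expected step from compound 3 to compound 4 is a 3.8-fold higher number from compound 3 to compound 4 (0.58 log units; beyond the scatter), a weakening of about the same size, resting on that one example only. Compound 4 is therefore expected to give about 380 nM in this assay, with a plausible span from 180 nM to 900 nM.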

Compound 4, half-maximal inhibitory concentration: 580 nM
Compound 4: middle estimate off by 1.5-fold (0.18 log units), on the low side; low and high end bracket the measured number.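

Putting methylamino in place of hydroxy on the saturated chain carbon bound to a carbonyl carbon, this time on the core of compound 3, gave a 5.8-fold higher number from compound 3 to compound 4 (0.76 log units; beyond the scatter) in this assay, so the weakening seen on the core of compound 1 appeared again. For the compounds shown here, the two steps point the same way and cannot be told apart in size: the same change on two cores in this assay, a 3.8-fold higher number (0.58 log units; beyond the scatter) from compound 1 to compound 2 and a 5.8-fold higher number (0.76 log units; beyond the scatter) from compound 3 to compound 4, 1.5-fold (0.19 log units) apart, within the scatter of two such steps This shows that the change carried over between these two cores in this one assay, but with only two pairs it does not show that it would carry over to any further core, and it says nothing about why the number rises.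

The compounds shown leave open how other groups would behave in the same place, such as a plain amino group, a dimethylamino group or a carboxylic acid. They also leave open whether a longer chain carrying the methylamino group would give a step of similar size.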